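The compounds below may be only part of what the source reports. "The series", "measured", "known", "first", "only" and "open" are said of these compounds alone.

Of the compounds shown here, three with a shared core have been measured in a physicochemical assay for solubility, measured as thermodynamic solubility, at pH 1.0; a lower number here means a less soluble compound, a higher number a more soluble compound. Compound 1 `O=C(Nc1ccc(Cl)c(-c2ccccn2)c1)c1ccc(-n2cncn2)nc1` gives 4000 ug/mL, compound 2 `Cc1ncn(-c2ccc(C(=O)Nc3ccc(Cl)c(-c4ccccn4)c3)c(C)n2)n1` gives 900 ug/mL, and compound 3 `CS(=O)(=O)Cc1ccc(C(=O)Nc2ccc(Cl)c(-c3ccccn3)c2)c(Cl)c1` gives 110 ug/mL. Compound 3 is the lowest of the three, and its gaps to the other two lie beyond the scatter.

The next compound, compound 4 `CS(=O)(=O)Nc1ccc(C(=O)Nc2ccc(Cl)c(-c3ccccn3)c2)c(Cl)c1`, differs from compound 3 in one place: methanesulfonamido in place of (methylsulfonyl)methyl on an aromatic carbon. Methanesulfonamido stands in place of (methylsulfonyl)methyl on an aromatic carbon, meta to a chloro group. Within the data shown here, the three measured compounds differ from one another in more than one place, so no measured pair isolates this exchange. The best available anchor is compound 3 at 110 ug/mL, which shares everything with compound 4 except this group. No step beyond the scatter is therefore expected in this assay, and the estimated step is a 1.1-fold lower number from compound 3 to compound 4 (0.04 log units; within the scatter). On these data alone, the direction remains open, and the range is kept wide. For compound 4 the estimate is 100 ug/mL, with an expected range from 30 ug/mL to 350 ug/mL.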

Compound 4, solubility: 910 ug/mL
The estimate for compound 4 lay 9.1-fold (0.96 log units) below the measured number, and the stated range ends below it.
By their numbers in this assay, from the lowest: compound 3; then compounds 2 and 4 (each within the scatter of the next); then compound 1.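

At this aromatic carbon, meta to a chloro group and para to a large group, a small change in the linking atom matters in this assay: methanesulfonamido in place of (methylsulfonyl)methyl gives an 8.3-fold higher number from compound 3 to compound 4 (0.92 log units; beyond the scatter) with the rest of the molecule unchanged. The two groups have the same count of heavy atoms and neither has a ring, and the counted differences are a nitrogen in place of a carbon and the hydrogen-bond donor that comes with it. No measurement shown here accounts for the step, so it cannot be tied to either difference.

On these data alone, it remains open whether a methyl group on the sulfonamide nitrogen would keep this step, and how a plain amine or a carboxylic acid at this carbon would compare. Also open, as far as these compounds go, is whether the same exchange gives a similar step on a ring without the chloro group.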